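The compounds below may be only part of what the source reports. "The series", "measured", "known", "first", "only" and "open" are said of these compounds alone.

Measured so far in a functional assay on A549 cells (Homo sapiens) for antiproliferative activity, read by MTT assay; on this read-out lower numbers stand for stronger inhibition and higher numbers for weaker inhibition:
Compound 1 `Cc1ccccc1NC(=O)Nc1cccc(CNc2ncnc3ccccc23)c1` gives 40200 nM.
Compound 2 `COc1cc2ncnc(NCc3cccc(NC(=O)Nc4ccc(C)cc4)c3)c2cc1OC` gives 12900 nM.
Compound 3 `COc1ccccc1NC(=O)Nc1cccc(CNc2ncnc3cc(OC)c(OC)cc23)c1` gives 15200 nM.

Compound 3 holds the second highest of the three numbers in this assay; its nearest is compound 2, within the scatter, and its furthest is compound 1, a gap beyond the scatter. Compound 4 `COc1cc2ncnc(NCc3cccc(NC(=O)Nc4ccccc4Cl)c3)c2cc1OC` differs from compound 3 by chloro in place of methoxy on an aromatic carbon. Among the compounds with values here, the one measured step that bears on this change, on the same aromatic ring, is a 1.2-fold higher number from compound 2 to compound 3 (0.07 log units; within the scatter), a step within the scatter. Substitution on that ring has so far not moved this assay beyond the scatter, so no step beyond the scatter is expected here either. Compound 4 is estimated at 15000 nM, range 7000 nM to 32000 nM, an expected step of a 1.0-fold lower number from compound 3 to compound 4 (0.01 log units; within the scatter).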

Compound 4, half-maximal inhibitory concentration: 15200 nM
Estimate against measurement, compound 4: 1.0-fold (0.01 log units) below; the measured number falls inside the stated range.
By their numbers in this assay, from the lowest: compounds 2, 3 and 4 (each within the scatter of the next); then compound 1.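

In this assay, chloro in place of methoxy on an aromatic carbon ortho to a large group gives (no change at the digits printed from compound 3 to compound 4 (within the scatter)), the first exchange read directly at this place. 2-Chlorophenyl in place of 4-methylphenyl gives (a 1.2-fold higher number from compound 2 to compound 4 (0.07 log units; within the scatter)), so compound 2, compound 3 and compound 4 all stay within the scatter of one another. No measurement available here explains this flat result.

On these data alone, whether an amine or a carboxylic acid on this ring would move the number remains open. Compound 1 differs from the others in more than one place, so no single change accounts for its gap.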